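Benzoyl to acetyl: what compound 3 may show

The source may hold more compounds than are shown below. What is called first, only, known or untested is meant among the compounds shown, and "the series" means these compounds.

In a physicochemical assay for solubility, with a stated time of 3 days, at pH 7 (a lower number here means a less soluble compound, a higher number a more soluble compound), compound 1 `COc1ccc(CN2CCC(CCOc3ccc(-c4nc5cc(C(N)=O)ccc5[nH]4)cc3)CC2)cc1` gives < 1000 nM, which is a limit of the assay and not a number. For the measured compounds named here, compound 2 `NC(=O)c1ccc2[nH]c(-c3ccc(OCCC4CCN(C(=O)c5ccccc5)CC4)cc3)nc2c1` gives 3000 nM, the only actual number so far. Compound 3 `CC(=O)N1CCC(CCOc2ccc(-c3nc4cc(C(N)=O)ccc4[nH]3)cc2)CC1` carries acetyl where compound 2 carries benzoyl: methyl in place of phenyl on a carbonyl carbon. Going by the values given here, the one measured step that bears on this is an at least 3.0-fold higher number from compound 1 to compound 2 (0.47 log units; beyond the scatter), with benzoyl in place of 4-methoxybenzyl on an amine nitrogen in a ring. That step is only a bound, resting on (the limit of < 1000 nM in this assay, at which 1 of the 2 values shown sits). No measurement tests the acetyl swap itself, so the expectation in this assay is loose: a modest move upward, with a wide margin. The expected change is a 2.3-fold higher number from compound 2 to compound 3 (0.37 log units; beyond the scatter). For compound 3 the estimate is 7000 nM, with an expected range of 2000 nM to 25000 nM.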

Compound 3, solubility: 2000 nM
For compound 3 the middle estimate is 3.5-fold (0.54 log units) above the measured one; measured number inside the range.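

In this assay, methyl in place of phenyl on a carbonyl carbon gives a 1.5-fold lower number from compound 2 to compound 3 (0.18 log units; within the scatter), so compound 2 and compound 3 stand level within the scatter, although methyl carries 1 heavy atom where phenyl carries 6. The change from 4-methoxybenzyl to acetyl on the ring nitrogen gives an at least 2.0-fold higher number from compound 1 to compound 3 (0.30 log units; that floor lies within the scatter), a second floor on that nitrogen, though a weaker one than the floor for benzoyl. Compound 1 gives < 1000 nM, a limit of the assay and not a number, so neither floor fixes the true size of its step: the limit of < 1000 nM in this assay, at which 1 of the 3 values shown sits.

As far as these compounds go, what a longer chain, an amine or a carboxylic acid on this carbonyl carbon would show in this assay remains open. So does the reading with a plain hydrogen on the ring nitrogen, with no carbonyl there at all.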